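Fluoro in Place of Hydrogen on a Second Core

The compounds below may be only part of what the source reports. "The series", "measured", "known", "first", "only" and "open" are said of these compounds alone.

Measured so far, in a functional assay on SW 1116 cells (Homo sapiens) for antiproliferative activity, read by MTT assay, with a stated time of 48 h; a higher number here means a weaker inhibitor, a lower number a stronger inhibitor:
- compound 1, `Fc1ccccc1CSc1nnc(-c2cnccn2)o1`: 16800 nM
- compound 2, `Fc1ccc(CSc2nnc(-c3cnccn3)o2)c(F)c1`: 19300 nM
- compound 3, `Fc1ccc(CSc2nnc(-c3cnccn3)s2)cc1`: 17100 nM

All three numbers sit close together, and none of the gaps among them is beyond the usual scatter, so no order of strength can be read from them.

Compound 1 and compound 2 differ in one place: fluoro in place of hydrogen on an aromatic carbon. This change gave a 1.1-fold higher number from compound 1 to compound 2 (0.06 log units; within the scatter), which is within the scatter, so it made no measurable difference on the core of compound 1.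

Compound 4, `Fc1ccc(CSc2nnc(-c3cnccn3)s2)c(F)c1`, has not yet been measured. It is built from compound 3 by the same kind of change: fluoro in place of hydrogen on an aromatic carbon. The surroundings are not quite the same, though: in the first pair the new fluoro sits meta to a fluoro group and para to a large group, while in the second pair it sits ortho to a large group and meta to a fluoro group. The difference between the core of compound 1 and the core of compound 3 is not broken down here.

Going by the values given here, the expectation rests on the one measured example. Because a 1.1-fold higher number from compound 1 to compound 2 (0.06 log units; within the scatter) was within the scatter, the step from compound 3 to compound 4 in this assay is estimated to be small as well, about a 1.1-fold higher number from compound 3 to compound 4 (0.03 log units; within the scatter). On that basis compound 4 is expected to give 18500 nM, most likely between 9000 nM and 38000 nM.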

Compound 4, half-maximal inhibitory concentration: 5180 nM
For compound 4 the middle estimate is 3.6-fold (0.55 log units) above the measured one; the whole stated range lies above it.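

In this assay, fluoro in place of hydrogen on an aromatic carbon gave a 3.3-fold lower number from compound 3 to compound 4 (0.52 log units; beyond the scatter), a modest step that makes compound 4 the stronger of this pair. Going by these compounds alone, the same change did not give the same result on the two cores, and the gap between the two steps is larger than repeat measurements alone would explain: the same change on two cores in this assay, a 1.1-fold higher number (0.06 log units; within the scatter) from compound 1 to compound 2 and a 3.3-fold lower number (0.52 log units; beyond the scatter) from compound 3 to compound 4, 3.8-fold (0.58 log units) apart, beyond the scatter of two such steps This rests on only two pairs, and the new fluoro has different surroundings in each; the result shows that the outcome of this change depends on where it is made, but it does not show whether the core, the position of the fluoro on the ring or both together account for the gap, and it does not tell what the step would be on a further core.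

The compounds shown leave open whether chloro, methoxy or trifluoromethyl at the same aromatic carbon would match the fluoro of compound 4. They also leave open what an amine or a carboxylic acid on that ring would do on either core, and whether a longer chain in place of the link to the ring would alter the step.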